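Methoxy-to-fluoro swap on the core, two compounds measured

A few compounds are considered here, and "the series" means these few. Any claim that something is new, unique, unknown or untested is made for them only; others in the source may bear on it.

Measured so far:
compound 1, `COc1ccc2c(=O)cc(-c3ccc(F)cc3)oc2c1`: "not active" (no number reported)
compound 2, `COc1ccc(-c2cc(=O)c3ccc(F)cc3o2)cc1`: 40%

Among the compounds with values here, in an in vitro assay on BTI-TN-5B1-4 cells for inhibition of Amine oxidase [flavin-containing] A (Homo sapiens), tested at 100 uM (a higher number here means more inhibition at the concentration tested (going by the name of the read-out), a lower number less inhibition), compound 2 gives 40%, the only number in the set. Compound 1 is reported in this assay as "not active" (no number reported), with no figure. Compound 3, `O=c1cc(-c2ccc(F)cc2)oc2cc(F)ccc12`, follows from compound 2 by fluoro in place of methoxy on an aromatic carbon. Within the data shown here, no step between measured compounds is available to size this change. With compound 1 reported as "not active" (no number reported) in this assay, a fall beyond the scatter is expected, a number 20 percentage points lower from compound 2 to compound 3 (beyond the scatter). Compound 3 is estimated at 20% in this assay, within 0% to 45%.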

Compound 3, a percentage reported as inhibition, at one concentration (the size of the read-out at that concentration, not a potency): "not active" (no number reported)
No number was reported for compound 3; there is nothing to compare the estimate with.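

Within the data shown here, compound 3, like compound 1, is reported without a number in this assay, so no step from compound 2 to compound 3 can be read. No supporting data bear on this result. The compounds shown leave open how large the effect of fluoro in place of methoxy is.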